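The compounds below may be only part of what the source reports. "The series", "measured", "known", "first", "only" and "open" are said of these compounds alone.

Measured compounds in an assay on isolated protein for inhibition of RAC-alpha serine/threonine-protein kinase (Homo sapiens), read by fluorescence, with a stated time of 30 min, tested at 10 uM; a higher number here means more inhibition at the concentration tested (going by the name of the read-out), a lower number less inhibition:
Compound 1, `O=C(Nc1cc(Sc2ncn[nH]2)c(O)c2ccccc12)c1ccc([N+](=O)[O-])cc1`: 37.3%
Compound 2, `O=C(Nc1cc(Sc2ncn[nH]2)c(O)c2ccccc12)c1cccc([N+](=O)[O-])c1`: 29.3%
Compound 3, `O=C(Nc1cc(Sc2ncn[nH]2)c(O)c2ccccc12)c1cccc(Cl)c1`: 46%

Compound 3 has the highest of the three numbers in this assay. Its nearest neighbour is compound 1, whose value lies lower by a number 8.7 percentage points higher from compound 1 to compound 3 (within the scatter), a gap within the scatter, so the two cannot be ordered; compound 2 lies furthest away, lower by a number 16.7 percentage points higher from compound 2 to compound 3 (beyond the scatter), which is beyond the scatter.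

Compound 4, `COc1ccc(C(=O)Nc2cc(Sc3ncn[nH]3)c(O)c3ccccc23)cc1`, is the next compound. It differs from compound 3 in one place: 4-methoxyphenyl in place of 3-chlorophenyl on a carbonyl carbon

For the measured compounds named here, two measured steps touch this change. The step of a number 16.7 percentage points higher from compound 2 to compound 3 (beyond the scatter) shows that exchanging chloro for nitro on the aromatic ring raised the number; the step of a number 8.7 percentage points higher from compound 1 to compound 3 (within the scatter) is within the scatter. Going by the values given here, no measured compound carries a methoxy group, so there is no direct precedent. Since both nitro-bearing compounds sit at or below compound 3, compound 4 is expected to come out somewhat lower, by about a number 11 percentage points lower from compound 3 to compound 4 (beyond the scatter), a step that could still fall within the scatter. For compound 4 the estimated value in this assay is 35%, with a range from 20% to 50%.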

Compound 4, a percentage reported as inhibition, at one concentration (the size of the read-out at that concentration, not a potency): 30.8%
Compound 4: the middle estimate sits 4.2 percentage points above what was measured; the range from low to high includes it.
By their numbers in this assay, from the lowest: compounds 2, 4, 1 and 3 (each within the scatter of the next, the first and the last beyond it).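

In this assay, for the compounds shown here, the first group on the carbonyl carbon that is neither nitro nor chloro, 4-methoxyphenyl in place of 3-chlorophenyl, gives a number 15.2 percentage points lower from compound 3 to compound 4 (beyond the scatter), so this position responds to a change beyond the nitro compounds, and compound 3 now stands clear of two of the other three, with compound 1 the exception. Methoxy does not separate from nitro: the changes give a number 1.5 percentage points higher from compound 2 to compound 4 (within the scatter) and a number 6.5 percentage points lower from compound 1 to compound 4 (within the scatter). Nothing available here accounts for the drop from the chloro compound.

The step from compound 3 to compound 4 changes both the group and the numbering of its place on the ring, so the two contributions remain unresolved. As far as these compounds go, how an amine or a carboxylic acid on this phenyl ring would read in this assay also remains open.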